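This account rests on a few compounds, and the source may have more. Where it says the series, first, only, none or still open, it means among the compounds named here.

Working notes on the series. Compound 1 `c1ccc2c(-c3cn4ccnc4c(-c4ccc5ncn(C6CCCCC6)c5c4)n3)cccc2c1` gives 9.45% in a functional assay on NCI-H226 cells (Homo sapiens) for inhibition, read by sulforhodamine B assay, with a stated time of 48 h, tested at 10 uM; a lower number here means less inhibition, a higher number more inhibition at the concentration tested (going by the name of the read-out). Among the compounds with values here, compound 2 `Brc1ccc(-c2cn3ccnc3c(-c3ccc4ncn(C5CCCCC5)c4c3)n2)cc1` gives 23.3% in this assay, and the single measured step, a number 13.9 percentage points higher from compound 1 to compound 2 (beyond the scatter), is the only change in the aryl group that has a number attached. Compound 3 `CCc1ccc(-c2cn3ccnc3c(-c3ccc4ncn(Cc5ccccc5)c4c3)n2)cc1` gives 1.48% in this assay; this number sits within the scatter of compound 1 and is separated from compound 2 by more than the scatter. Compound 4 `Cc1cccc(-c2cn3ccnc3c(-c3ccc4ncn(Cc5ccccc5)c4c3)n2)c1` differs from compound 3 by 3-methylphenyl in place of 4-ethylphenyl on an aromatic carbon. The step from compound 1 to compound 2 also replaces one aryl group with another on an aromatic carbon of the core, and it moved the read-out modestly; it carries over only loosely, since compound 3 and compound 4 bear a benzyl group on the core where compound 1 and compound 2 bear a cyclohexyl group. Exchanging one plain aryl group for another is expected to give no step beyond the scatter, a number 4.5 percentage points higher from compound 3 to compound 4 (within the scatter). Compound 4 is therefore estimated at 6% in this assay, between -6% and 22%.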

Compound 4, a percentage reported as inhibition, at one concentration (the size of the read-out at that concentration, not a potency): 1.18%
Estimate against measurement, compound 4: 4.8 percentage points above, within the range that was stated.
By their numbers in this assay, from the lowest: compounds 4, 3 and 1 (each within the scatter of the next); then compound 2.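

In this assay, 3-methylphenyl in place of 4-ethylphenyl gives a number 0.3 percentage points lower from compound 3 to compound 4 (within the scatter), so this exchange of one alkyl-substituted phenyl group for another, on this aromatic carbon of the shared core, leaves the read-out within the scatter. Within the data shown here, this is the first step at this position with a benzyl group on the core, whereas the earlier step, a number 13.9 percentage points higher from compound 1 to compound 2 (beyond the scatter), was measured with a cyclohexyl group there and involved different aryl groups. The data shown offer no measured basis for explaining the result at this position.

On these data alone, whether 4-bromophenyl would shift the read-out with the benzyl group on the core remains open. So does the outcome for a phenyl group carrying an amine or a carboxylic acid at this position.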